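From Compound 3 to Compound 4 at the Histamine Receptor

The source may hold more compounds than are shown below. What is called first, only, known or untested is meant among the compounds shown, and "the series" means these compounds.

Compound 1, `CN/C(=N/C#N)NCCCCc1c[nH]c(C)n1`: in a functional assay on Sf9 cells for antagonist activity at histamine H2 receptor (Homo sapiens), read by scintillation counting and GTPgammaS binding, with a stated time of 90 min (on this read-out lower numbers stand for lower potency and higher numbers for higher potency (the scale is a negative logarithm)), compound 1 gives only a limit, < 5.
Compound 2, `CN/C(=N/C#N)NCCCCc1nc[nH]c1C`: in this assay compound 2 likewise gives only a limit, < 5.
Compound 3, `Cc1[nH]cnc1CCCCN/C(=N\C#N)NCCSc1ccccc1`: in this assay compound 3 gives 5.36.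

Going by the values given here, compound 3 is thus the only member with a real number; the other two sit at the limit of < 5 in this assay, at which 2 of the 3 values shown sit. Among the compounds with values here, the one measured step that ends at compound 3, a number at least 0.36 log units higher from compound 2 to compound 3 (beyond the scatter), adds a (phenylsulfanyl)methyl group on a saturated chain carbon bound to an amine nitrogen.

Compound 4, `Cc1nccn1CCCCCN/C(=N\C#N)NCCSc1ccccc1`, is not yet measured. It differs from compound 3 in a different place: (2-methyl-1H-imidazol-1-yl)methyl in place of 5-methyl-1H-imidazol-4-yl on a saturated chain carbon, four bonds along the chain from an amine nitrogen. Within the data shown here, no measured step touches this kind of change, so the step from compound 2 to compound 3 gives no guidance on its direction or size. With nothing to lean on, compound 4 is expected to land near the value of its parent, at 5, within a wide range from 4.2 to 5.8. The step this implies, a number 0.36 log units lower from compound 3 to compound 4 (beyond the scatter), is only an estimate, and a result that is again just a limit remains quite possible.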

Compound 4, negative logarithm of the antagonist equilibrium constant: < 5
Compound 4 gave a limit, no number; the forecaster's own chance of this, stated with the estimate: 50%; the middle value sits exactly at the limit.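

Swapping 5-methyl-1H-imidazol-4-yl for (2-methyl-1H-imidazol-1-yl)methyl gives a number at least 0.36 log units lower from compound 3 to compound 4 (beyond the scatter) and so shows that this place on the chain, which no earlier step touched, is not free to change. The entering group keeps a five-membered aromatic ring with 2 hetero atoms but has 0 hydrogen-bond donors against 1, so a similar ring alone does not keep a measurable value here. Compound 4 gives only a limit and joins the other compounds without a number: the limit of < 5 in this assay, at which 3 of the 4 values shown sit.

Which part of the swap matters stays open, since the ring attachment, the methyl placement and the chain length all change together. The compounds shown also do not tell how a piperidine ring or a longer chain would read in this assay at this place.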